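Adding a Formyl Group to a Core Without Measured Activity

The compounds below may be only part of what the source reports. "The series", "measured", "known", "first", "only" and "open" are said of these compounds alone.

Compound 1 `Fc1ccc(-c2cn3nc(Cc4ccc(Cl)cc4)sc3n2)cc1` was tested in an ADME assay on CCRF-CEM cells (Homo sapiens) for cytotoxicity, with a stated time of 72 h; on this read-out lower numbers stand for stronger inhibition and higher numbers for weaker inhibition. In this assay compound 1 gives > 250000 nM, which is a limit of the assay rather than a measured number. So only a limit is known for compound 1, and the one other value shown is a limit as well. Its close relative compound 2 `Clc1ccc(Cc2nn3cc(-c4ccccc4)nc3s2)cc1` differs only by hydrogen in place of fluoro on an aromatic carbon. In this assay compound 2 gives > 250000 nM, again a limit. Between them lies a step that the two limits leave unreadable from compound 1 to compound 2, so the effect of that change cannot be read; what is known is the limit of > 250000 nM in this assay, at which 2 of the 2 values shown sit.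

The unmeasured compound 3 `O=Cc1c(-c2ccc(F)cc2)nc2sc(Cc3ccc(Cl)cc3)nn12` keeps the core of compound 1 but carries formyl in place of hydrogen on an aromatic carbon. Among the compounds with values here, no measured step involves a formyl group, and the one comparison available is unreadable, so nothing suggests a change beyond the scatter in this assay. Compound 3 is therefore expected to sit at the same limit, with a step that the limit leaves unreadable from compound 1 to compound 3 estimated. The estimate for compound 3 is 300000 nM, within 80000 nM to 1000000 nM.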

Compound 3, half-maximal inhibitory concentration: 17000 nM
Compound 3: the middle estimate sits 18-fold (1.25 log units) above what was measured; measured number outside the range, below it.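

In this assay, within the data shown here, formyl in place of hydrogen on this aromatic carbon gives an at least 14-fold lower number from compound 1 to compound 3 (1.16 log units; beyond the scatter), the first step that can be read, as the step from compound 1 to compound 2 cannot. This shows that the carbon next to the ring atom that bears a 4-fluorophenyl group is a place where a small addition to the core of compound 1 can bring the read-out from no measured number to a real one, with lower numbers meaning stronger inhibition. Compound 1 and compound 2 stay at a limit of the assay rather than a number: the limit of > 250000 nM in this assay, at which 2 of the 3 values shown sit.

Whether the gain belongs to the formyl group itself or would come with other groups on this carbon stays open, since a hydroxymethyl group, a carboxylic acid, a nitrile or an amine there has no value among the compounds shown. Going by these compounds, it is also open whether the same formyl group would act in the same way on the core of compound 2, which has hydrogen in place of the fluoro group, as the step is seen on one core only.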